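Methoxy Added to a Fused Core: Expected Shift

A few compounds are considered here, and "the series" means these few. Any claim that something is new, unique, unknown or untested is made for them only; others in the source may bear on it.

Of the compounds shown here, three sharing a common amide chain have been tested in a functional assay on HCT-116 cells (Homo sapiens) for inhibition, read by colorimetric assay, with a stated time of 3 days; on this read-out lower numbers stand for stronger inhibition and higher numbers for weaker inhibition. Compound 1 `COc1ccc(-c2cnc(NC(=O)CCCCCCNC(=O)C(O)(O)C(F)(F)F)s2)cc1` gives 930 nM. Compound 2 `O=C(CCCCCCNC(=O)C(O)(O)C(F)(F)F)Nc1ncc(-c2ccccc2)s1` gives 2660 nM. Compound 3 `O=C(CCCCCCNC(=O)C(O)(O)C(F)(F)F)Nc1nc2ccccc2s1` gives 2370 nM.

Between compound 2 and compound 1 the change is methoxy in place of hydrogen on an aromatic carbon, and it made a 2.9-fold lower number from compound 2 to compound 1 (0.46 log units; beyond the scatter). The difference between the cores of compound 2 and compound 3 is not broken down here; the numbers for compound 3 and compound 2 lie within the scatter of each other.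

Compound 4 `COc1ccc2nc(NC(=O)CCCCCCNC(=O)C(O)(O)C(F)(F)F)sc2c1` has not yet been measured. From compound 3 it differs by methoxy in place of hydrogen on an aromatic carbon. Within the data shown here, this is the same kind of change as the one from compound 2 to compound 1, but the surroundings differ: in compound 1 the methoxy sits para to a large group, whereas in compound 4 it sits on a six-membered ring that is part of a fused or bridged system of two rings, meta to a fused ring and para to a fused ring. Among the measured compounds shown here, the expected step is a 2.0-fold lower number from compound 3 to compound 4 (0.30 log units; within the scatter), kept a little smaller than the earlier one because a 2.9-fold lower number from compound 2 to compound 1 (0.46 log units; beyond the scatter) is the only example of this kind of change and was made in a different setting. Compound 4 is therefore estimated at 1200 nM in this assay, with a likely range from 500 nM to 3000 nM.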

Compound 4, half-maximal inhibitory concentration: 7560 nM
Compound 4: middle estimate off by 6.3-fold (0.80 log units), on the low side; the whole stated range lies below it.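

In this assay the same methoxy change that lowered the number on the earlier core gives a 3.2-fold higher number from compound 3 to compound 4 (0.50 log units; beyond the scatter) on the fused core, so the step runs the opposite way. The two cases clearly disagree, and a step read on one core did not carry over to the other here: the same change on two cores in this assay, a 2.9-fold lower number (0.46 log units; beyond the scatter) from compound 2 to compound 1 and a 3.2-fold higher number (0.50 log units; beyond the scatter) from compound 3 to compound 4, 9.1-fold (0.96 log units) apart, beyond the scatter of two such steps. Among these compounds, this shows that the effect of this change depends on the core that carries it, but with only two pairs it does not show which feature of the cores matters, nor does it give a rule for any further core.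

A third core carrying the same change would show whether either direction is the more usual one in this series. On these data alone, it also remains open whether a hydroxy group or a chlorine atom in place of that hydrogen would split between the two cores in the same way.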